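Methyl for bromo on the amino compounds

This account rests on a few compounds, and the source may have more. Where it says the series, first, only, none or still open, it means among the compounds named here.

In a functional assay on MOLT-4 cells (Homo sapiens) for antiproliferative activity, with a stated time of 48 h (a higher number here means a weaker inhibitor, a lower number a stronger inhibitor), compound 3 (`Nc1ccc(/C=C/C(=O)c2ccc(Br)cc2)cc1`) gives 10000 nM, level with compound 2 (`Nc1ccc(/C=C/C(=O)c2ccccc2)cc1`) at 10000 nM. Going by the values given here, these two share the highest of the three numbers so far. Compound 1 (`C=C(Br)C(=O)Nc1ccc(/C=C/C(=O)c2ccc(C)cc2)cc1`) sits clearly lower at 1700 nM.

The next compound, compound 4 (`Cc1ccc(C(=O)/C=C/c2ccc(N)cc2)cc1`), comes from compound 3 by one change: methyl in place of bromo on an aromatic carbon, para to a large group (methyl in place of bromo on an aromatic carbon).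

The closest evidence is the measured change at the same place, bromo in place of hydrogen on an aromatic carbon: no change at the digits printed from compound 2 to compound 3 (within the scatter). That step stays within the scatter, so this substituent has not yet moved the number in the free amine compounds. Compound 1 also carries the methyl, but it has an amide where compound 4 has the free amine. The number of compound 1 at 1700 nM is therefore no direct guide to the effect of the methyl alone.

No shift beyond the scatter is expected in this assay, and no direction is favoured. The expected change is no change at the digits printed from compound 3 to compound 4 (within the scatter). For compound 4 the estimated value is 10000 nM, with an expected range of 5000 nM to 20000 nM.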

Compound 4, half-maximal inhibitory concentration: 12000 nM
Compound 4: the middle estimate sits 1.2-fold (0.08 log units) below what was measured, within the range that was stated.
By their numbers in this assay, from the lowest: compound 1; then compounds 2, 3 and 4 (each within the scatter of the next).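

In this assay the steps of a 1.2-fold higher number from compound 3 to compound 4 (0.08 log units; within the scatter) and a 1.2-fold higher number from compound 2 to compound 4 (0.08 log units; within the scatter) now place hydrogen, bromo and methyl level with one another on this aromatic carbon, para to a large group, in the free amine compounds. Going by these compounds alone, with methyl on both sides, the nitrogen can now be read as a single change: a 7.1-fold higher number from compound 1 to compound 4 (0.85 log units; beyond the scatter) with hydrogen in place of (1-bromoethenyl)carbonyl on a nitrogen on an aromatic ring, the only one-place step so far that lies beyond the scatter. No measurement bears on the cause of either result.

Still open, from the compounds shown here alone, is whether a methoxy, a carboxylic acid or a longer chain at this aromatic carbon would separate from hydrogen, bromo and methyl, or whether this position stays flat in the free amine compounds. Also open, going by these compounds, is whether the lower number of the amide depends on the bromine and the ethenyl part of the (1-bromoethenyl)carbonyl group, which a plain acetyl on the nitrogen would test, and whether bromo or hydrogen in place of methyl matters once that amide is present.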